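Expected Cytotoxicity of Compound 4 After Adding a Carboxy Group

A few compounds are considered here, and "the series" means these few. Any claim that something is new, unique, unknown or untested is made for them only; others in the source may bear on it.

Values in an ADME assay on HEK293 cells (Homo sapiens) for cytotoxicity, with a stated time of 72 h (a lower number here means that less compound is needed, a higher number that more compound is needed for the effect), for the three measured compounds:
compound 1 `O=C(Nc1cc(-c2nc3ccccc3s2)ccc1Cl)c1cc([N+](=O)[O-])ccc1Cl`: > 25000 nM
compound 2 `Cc1ccc(-c2nc3ccccc3s2)cc1NC(=O)c1cc([N+](=O)[O-])c(N2CCCCC2)cc1Cl`: > 25000 nM
compound 3 `O=C(Nc1cccc(-c2nc3ccccc3s2)c1)c1cc([N+](=O)[O-])c(O)cc1Cl`: > 25000 nM

Each of these three values is a limit of the assay, not a measured number. Compound 2 therefore stands at the limit, and every other value shown sits at the same point, as summarised by the limit of > 25000 nM in this assay, at which 3 of the 3 values shown sit.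

Compound 4 `Cc1ccc(-c2nc3ccccc3s2)cc1NC(=O)c1cc([N+](=O)[O-])c(N2CCC(C(=O)O)CC2)cc1Cl` has not been measured. It differs from compound 2 in one place: carboxy in place of hydrogen on a saturated ring carbon. Among the compounds with values here, no measured step between two compounds is available, so the data give no direction for this change in this assay. I expect no step beyond the scatter, most likely a limit again. The expected step is a step that the limit leaves unreadable from compound 2 to compound 4. Compound 4 is therefore expected to give about 40000 nM, in a range from 20000 nM to 100000 nM.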

Compound 4, half-maximal effective concentration: > 25000 nM
Compound 4 was reported as a limit (the forecaster's own chance of this, stated with the estimate: 85%); the middle value is on the limit's open side.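

No step can be read from compound 2 to compound 4, since both are reported only as limits in this assay: the limit of > 25000 nM in this assay, at which 4 of the 4 values shown sit.

The compounds shown leave open what concentration, if any, produces the effect, and so whether carboxy in place of hydrogen changes it.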